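Amide variation in a chalcone series: notes toward compound 4

The source may hold more compounds than are shown below. What is called first, only, known or untested is meant among the compounds shown, and "the series" means these compounds.

Measured so far in a functional assay on Vero cells (Chlorocebus sabaeus) for inhibition; on this read-out higher numbers stand for weaker inhibition and lower numbers for stronger inhibition:
compound 1 `COc1cc(/C=C/C(=O)c2cccc(NC(=O)c3ccco3)c2)ccc1O` gives 3.11 ug/mL
compound 2 `COc1cc(/C=C/C(=O)c2cccc(NC(=O)C(C)C)c2)ccc1O` gives 3.47 ug/mL
compound 3 `CCCC(=O)Nc1cccc(C(=O)/C=C/c2ccc(O)c(OC)c2)c1` gives 2.04 ug/mL

Compound 1 holds the second highest of the three numbers in this assay; its nearest neighbour is compound 2 and its furthest is compound 3, both within the scatter of it. Compound 4 `COc1cc(/C=C/C(=O)c2cccc(NC(C)=O)c2)ccc1O` is the next entry. Its change from compound 1: methyl in place of furan-2-yl on a carbonyl carbon. Within the data shown here, two measured steps bear on this, each replacing furan-2-yl on the same carbonyl carbon: a 1.1-fold higher number from compound 1 to compound 2 (0.05 log units; within the scatter) and a 1.5-fold lower number from compound 1 to compound 3 (0.18 log units; within the scatter). Neither moved the number beyond the scatter, so no step beyond the scatter is expected for a 1.1-fold lower number from compound 1 to compound 4 (0.03 log units; within the scatter). Compound 4 is therefore estimated at 2.9 ug/mL, with a range from 1.5 ug/mL to 5.6 ug/mL.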

Compound 4, half-maximal inhibitory concentration: 14.5 ug/mL
Compound 4: the middle estimate sits 5.0-fold (0.70 log units) below what was measured, outside the stated range (above it).
By their numbers in this assay, from the lowest: compounds 3, 1 and 2 (each within the scatter of the next); then compound 4.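

On this assay, this carbonyl carbon does not tolerate every group: methyl gives a 4.7-fold higher number from compound 1 to compound 4 (0.67 log units; beyond the scatter), while a 4.2-fold higher number from compound 2 to compound 4 (0.62 log units; beyond the scatter) and a 7.1-fold higher number from compound 3 to compound 4 (0.85 log units; beyond the scatter) show the same separation from the isopropyl and propyl amides. Furan-2-yl, isopropyl and propyl remain within the scatter of one another, so among these four groups only methyl stands apart. Nothing available bears on the reason for this shift.

As far as these compounds go, whether ethyl falls with methyl or with propyl remains open. So does whether a longer chain such as hexyl, or a terminal amine on the chain, keeps the number near that of compound 3.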